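Swapping methoxy for nitro on a growth-inhibiting compound

The source may report more compounds than this note shows. Statements on the series, on what has been measured and on what is new or still open speak of the compounds shown alone.

compound 1 `COc1ccc(Cc2nnc(NC(=O)/C(C#N)=C/c3ccccc3OS(=O)(=O)c3ccc([N+](=O)[O-])cc3)s2)cc1`: 51%
compound 2 `COc1ccc(S(=O)(=O)Oc2ccccc2/C=C(\C#N)C(=O)Nc2nnc(Cc3ccccc3)s2)cc1`: 100%

In a functional assay on HL-60 cells (Homo sapiens) for inhibition, read by CCK-8 assay, with a stated time of 48 h, tested at 20 uM (a higher number here means more inhibition of growth at the concentration tested, a lower number less inhibition of growth), compound 2 stands highest of the two measured compounds at 100%. Compound 1 gives 51%. The gap between these two values lies beyond the usual scatter. Compound 3 `N#C/C(=C\c1ccccc1OS(=O)(=O)c1ccc([N+](=O)[O-])cc1)C(=O)Nc1nnc(Cc2ccccc2)s1` differs from compound 2 in one place: nitro in place of methoxy on an aromatic carbon. This puts nitro in place of methoxy on an aromatic carbon, turning 4-methoxyphenyl into 4-nitrophenyl. For the measured compounds named here, no measured pair shows this change alone. Compound 1 also carries 4-nitrophenyl and gives 51%, so a fall beyond the scatter is expected. The estimated change is a number 30 percentage points lower from compound 2 to compound 3 (beyond the scatter). The estimate for compound 3 is 70%, within a range of 42% to 100%.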

Compound 3, percent growth inhibition at one concentration: 20%
Compound 3: the middle estimate sits 50 percentage points above what was measured, outside the stated range (below it).
By their numbers in this assay, from the lowest: compound 3; then compound 1; then compound 2.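

In this assay, this position on the sulfonyl-bound ring proves highly sensitive: nitro in place of methoxy, turning 4-methoxyphenyl into 4-nitrophenyl, gives a number 80 percentage points lower from compound 2 to compound 3 (beyond the scatter). The other end of the molecule also counts: with 4-nitrophenyl kept, hydrogen in place of methoxy on the other aromatic ring gives a number 31 percentage points lower from compound 1 to compound 3 (beyond the scatter), so methoxy goes with more growth inhibition in both steps. Nothing measured here gives a reason for either fall. The compounds shown leave open whether an amine, a methyl or a chlorine at the first position would bring the number nearer that of compound 2 or that of compound 3.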